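This account rests on a few compounds, and the source may have more. Where it says the series, first, only, none or still open, it means among the compounds named here.

Measured so far:
compound 1 `N#CC1CC(=O)N(c2cnn3c2CN(C(=O)Nc2cc(F)c(F)c(F)c2)C(C2CC2)C3)C1` 10600 ng.h/mL
compound 2 `O=C1CC(c2ncco2)CN1c1cnn2c1CN(C(=O)Nc1cc(F)c(F)c(F)c1)C(C1CC1)C2` 12200 ng.h/mL
compound 3 `C[C@H]1Cn2ncc(N3CC(c4ccccc4)CC3=O)c2CN1C(=O)Nc1cc(F)c(F)c(F)c1` 6510 ng.h/mL

In an ADME assay on the whole organism (Mus musculus, strain ICR) for pharmacokinetics, at a dose of 50 mg/kg by the oral route (a higher number here means more compound in the circulation at the dose given, a lower number less compound in the circulation), compound 1 gives 10600 ng.h/mL, which lies within the scatter of both compound 2 and compound 3, so the three numbers set no order. The change to compound 4 `Cc1nc(C2CC(=O)N(c3cnn4c3CN(C(=O)Nc3cc(F)c(F)c(F)c3)C(C3CC3)C4)C2)no1` is 5-methyl-1,2,4-oxadiazol-3-yl in place of cyano on a saturated ring carbon, with 5-methyl-1,2,4-oxadiazol-3-yl in place of cyano on a saturated ring carbon. Among the measured compounds shown here, the one measured step bearing on this is a 1.2-fold higher number from compound 1 to compound 2 (0.06 log units; within the scatter), where 1,3-oxazol-2-yl replaces cyano on that ring carbon. On the strength of that step, no change beyond the scatter is expected in this assay, in either direction. The expected step is a 1.0-fold higher number from compound 1 to compound 4 (0.02 log units; within the scatter). Compound 4 is estimated at 11000 ng.h/mL, with an expected range of 5000 ng.h/mL to 23000 ng.h/mL.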

Compound 4, area under the concentration-time curve: 3860 ng.h/mL
Compound 4: middle estimate off by 2.8-fold (0.45 log units), on the high side; measured number outside the range, below it.
By their numbers in this assay, from the lowest: compounds 4, 3, 1 and 2 (each within the scatter of the next, the first and the last beyond it).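

In this assay, the saturated ring carbon two ring bonds from the ring nitrogen does not accept every five-membered aromatic ring in place of cyano alike: 5-methyl-1,2,4-oxadiazol-3-yl gives a 2.7-fold lower number from compound 1 to compound 4 (0.44 log units; beyond the scatter) and, in place of 1,3-oxazol-2-yl, a 3.2-fold lower number from compound 2 to compound 4 (0.50 log units; beyond the scatter) on the same carbon. The within-scatter step seen with 1,3-oxazol-2-yl therefore does not extend to all such rings at this position. No measurement at hand bears on the reason for the lower number.

Going by these compounds, whether the lower number goes with the oxadiazole ring itself or with its methyl remains open. Also open, on these data alone, is how an amine or a carboxylic acid on this ring carbon would behave.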